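Amide chain variation on the iodophenyl sulfonate series

A few compounds are considered here, and "the series" means these few. Any claim that something is new, unique, unknown or untested is made for them only; others in the source may bear on it.

Among the compounds with values here, compound 3 `CC(C)C(=O)Nc1ccc(S(=O)(=O)Oc2ccccc2I)cc1` gives the lowest number measured so far in a functional assay on MCF7 cells (Homo sapiens) for antiproliferative activity, read by sulforhodamine B assay, with a stated time of 48 h (on this read-out higher numbers stand for weaker inhibition and lower numbers for stronger inhibition), at 8100 nM. Compound 2 `CCCCCC(=O)Nc1ccc(S(=O)(=O)Oc2ccccc2I)cc1` gives 10000 nM in this assay, and with a 1.2-fold lower number from compound 2 to compound 3 (0.09 log units; within the scatter) the two cannot be told apart. Compound 1 `CC(=O)Nc1ccc(S(=O)(=O)Oc2ccccc2I)cc1` gives 27000 nM in this assay; the steps of a 3.3-fold lower number from compound 1 to compound 3 (0.52 log units; beyond the scatter) and a 2.7-fold lower number from compound 1 to compound 2 (0.43 log units; beyond the scatter) are both beyond the scatter.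

Compound 4 `O=C(CCCl)Nc1ccc(S(=O)(=O)Oc2ccccc2I)cc1` differs from compound 3 by 2-chloroethyl in place of isopropyl on a carbonyl carbon. The two steps that enlarge the group on the carbonyl carbon of compound 1, a 2.7-fold lower number from compound 1 to compound 2 (0.43 log units; beyond the scatter) and a 3.3-fold lower number from compound 1 to compound 3 (0.52 log units; beyond the scatter), are modest, while the exchange of one larger group for another, a 1.2-fold lower number from compound 2 to compound 3 (0.09 log units; within the scatter), stays within the scatter. The change to compound 4 exchanges one group for another of the same heavy-atom count on the carbonyl carbon, so no step beyond the scatter is expected in this assay. Compound 4 is therefore estimated at 10000 nM in this assay, with a range from 4000 nM to 25000 nM. This estimate corresponds to an expected step of a 1.2-fold higher number from compound 3 to compound 4 (0.09 log units; within the scatter), within the scatter.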

Compound 4, half-maximal inhibitory concentration: 8900 nM
Compound 4: the middle estimate sits 1.1-fold (0.05 log units) above what was measured; low and high end bracket the measured number.
By their numbers in this assay, from the lowest: compounds 3, 4 and 2 (each within the scatter of the next); then compound 1.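

In this assay, the 2-chloroethyl group on the carbonyl carbon cannot be told apart from the all-carbon groups: neither a 1.1-fold higher number from compound 3 to compound 4 (0.04 log units; within the scatter) nor a 1.1-fold lower number from compound 2 to compound 4 (0.05 log units; within the scatter) separates the pair, so a chlorine in the chain gives no readable difference from isopropyl or pentyl. Measured against compound 1, the group holds up as well, with a 3.0-fold lower number from compound 1 to compound 4 (0.48 log units; beyond the scatter) as a modest step, which makes compounds 2, 3 and 4 all better than the methyl of compound 1, with none of the three going against this. No measurement here explains why these groups read alike.

Open, on these data alone, is whether an amine or a carboxylic acid at the end of the chain would separate from compounds 2, 3 and 4. Also open, as far as these compounds go, is how a phenyl ring on the carbonyl carbon, or a chain longer than pentyl, would read in this assay.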